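Cyclohexyl in Place of Methyl, Against an Assay Limit

The source may hold more compounds than are shown below. What is called first, only, known or untested is meant among the compounds shown, and "the series" means these compounds.

- Compound 1 `COC(=O)c1ccsc1NC(=O)[C@@H]1CCCN1`: > 250 ug/mL
- Compound 2 `O=C(OCc1ccccc1)c1ccsc1NC(=O)[C@@H]1CCCN1`: > 250 ug/mL
- Compound 3 `O=C(Oc1ccccc1)c1ccsc1NC(=O)[C@@H]1CCCN1`: > 250 ug/mL

In a functional assay on HeLa cells (Homo sapiens) for inhibition (on this read-out lower numbers stand for stronger inhibition of growth and higher numbers for weaker inhibition of growth), compound 1 stands at > 250 ug/mL, which is a limit and not a number. The other two entries are limits as well, and the whole record comes down to the limit of > 250 ug/mL in this assay, at which 3 of the 3 values shown sit.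

Compound 4 `O=C(OC1CCCCC1)c1ccsc1NC(=O)[C@@H]1CCCN1` departs from compound 1 by cyclohexyl in place of methyl on an oxygen next to a carbonyl group. Two measured steps also alter the group on that oxygen: a step that the two limits leave unreadable from compound 1 to compound 2, and a step that the two limits leave unreadable from compound 2 to compound 3. Neither gives a size to carry over. With a step that the two limits leave unreadable from compound 1 to compound 3 as the closest case, no step beyond the scatter is expected in this assay, in either direction, and another limit is the likeliest report. The expected change is a number no higher from compound 1 to compound 4 (the limit leaves the size open). For compound 4 the estimated value is 250 ug/mL, with an expected range from 100 ug/mL to 400 ug/mL.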

Compound 4, concentration for 50% growth inhibition: 92.8 ug/mL
Compound 4: the middle estimate sits 2.7-fold (0.43 log units) above what was measured; the measured number lies below the stated range.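

In this assay, the position on an oxygen next to a carbonyl group gives its first readable result, with an at least 2.6-fold lower number from compound 1 to compound 4 (0.43 log units; beyond the scatter), and the same holds against phenyl, with an at least 2.6-fold lower number from compound 3 to compound 4 (0.43 log units; beyond the scatter), and against benzyl, with an at least 2.6-fold lower number from compound 2 to compound 4 (0.43 log units; beyond the scatter). The read-out at this position therefore responds to the group placed there: of the groups shown, only cyclohexyl, with its six-membered non-aromatic ring of carbon only, gives a number, while methyl, benzyl and phenyl do not. The steps among compound 1, compound 2 and compound 3 cannot be read, and the sizes of the new steps stay open at one end: the limit of > 250 ug/mL in this assay, at which 3 of the 4 values shown sit.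

Going by these compounds, whether cyclopentyl or an open hexyl chain on that oxygen would also give a number remains open. So does the effect of an amine or a hydroxyl group on the cyclohexyl ring.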